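Swapping the aryl for a hexyl chain on the diacylhydrazine core

The compounds below may be only part of what the source reports. "The series", "measured", "known", "first", "only" and "open" are said of these compounds alone.

Compound 1 `CC(C)(C)N(NC(=O)c1cccc(F)c1)C(=O)c1ccccc1Cl`: 69.2 nM
Compound 2 `CC(C)(C)N(NC(=O)c1ccc(C#N)cc1)C(=O)c1ccccc1Cl`: 603 nM

Compound 2 gives the higher of the two numbers in an assay on cells for agonist activity at ecdysone receptor (Bombyx mori), read by a luciferase reporter, with a stated time of 24 h; on this read-out lower numbers stand for an effect already at smaller amounts and higher numbers for an effect only at larger amounts of compound; the step of an 8.7-fold higher number from compound 1 to compound 2 (0.94 log units; beyond the scatter) is the only one measured. Compound 3 `CCCCCCC(=O)NN(C(=O)c1ccccc1Cl)C(C)(C)C` differs from compound 2 by hexyl in place of 4-cyanophenyl on a carbonyl carbon. Among the compounds with values here, the one measured step concerns a change on the same carbonyl carbon and was modest, but it did not replace the ring itself, so the data give only a weak guide. Compound 3 is expected to move further to a higher number, estimated at 2000 nM with a range of 500 nM to 8000 nM, a step of a 3.3-fold higher number from compound 2 to compound 3 (0.52 log units; beyond the scatter).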

Compound 3, half-maximal effective concentration: 741 nM
Beside the measured number, compound 3's estimate is 2.7-fold (0.43 log units) above it, within the range that was stated.
By their numbers in this assay, from the lowest: compound 1; then compounds 2 and 3 (each within the scatter of the next).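

In this assay, an aromatic ring on this carbonyl carbon proves not to be required for the level of compound 2, since the open hexyl chain cannot be told apart from 4-cyanophenyl (a 1.2-fold higher number from compound 2 to compound 3 (0.09 log units; within the scatter)). Compound 1, with 3-fluorophenyl at the same place, stays clearly apart (an 11-fold higher number from compound 1 to compound 3 (1.03 log units; beyond the scatter)). Nothing available accounts for this result. The compounds shown leave open whether a longer chain or a cyclohexyl group on this carbonyl carbon would stay at this level. As far as these compounds go, whether an unsubstituted phenyl would fall with compound 1 or with compound 3 also remains open.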